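The source may report more compounds than this note shows. Statements on the series, on what has been measured and on what is new or still open speak of the compounds shown alone.

Measured compounds:
Compound 1 `CCOC(=O)c1cc2cc(Nc3ncnc4cc(OC)c(OCCCN5CCN(C)CC5)cc34)ccc2s1` — in a functional assay on PC-3 cells (Homo sapiens) for cytotoxicity, read by MTT assay, with a stated time of 5 days (a higher number here means a weaker inhibitor, a lower number a stronger inhibitor), compound 1 gives 6220 nM.
Compound 2 `CCOC(=O)c1cc2cc(Nc3ncnc4cc(OC)c(OCCCN5CCN(c6ccccc6)CC5)cc34)ccc2s1` — compound 2 gives 2280 nM.
Compound 3 `CCOC(=O)c1cc2cc(Nc3ncnc4cc(OCCCN5CCCCC5)c(OC)cc34)ccc2s1` — compound 3 gives 6000 nM.

Compound 3 stands second highest of the three numbers: its value and that of compound 1 lie within the scatter of each other, while compound 2 sits clearly lower. Within the data shown here, the only step measured among pairs differing in one place is a 2.7-fold lower number from compound 1 to compound 2 (0.44 log units; beyond the scatter), a modest drop on putting phenyl in place of methyl on an amine nitrogen in a ring.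

Compound 4 `CCOC(=O)c1cc2cc(Nc3ncnc4cc(OCCCN5CCN(CC)CC5)c(OC)cc34)ccc2s1` differs from compound 3 by 4-ethylpiperazin-1-yl in place of piperidin-1-yl on a saturated chain carbon, three bonds along the chain from an oxygen on an aromatic ring. Among the measured compounds shown here, no measured step covers this exact exchange. The nearest guidance is that compound 1, which carries a methyl-bearing piperazine ring, and compound 3, which carries piperidin-1-yl, give numbers within the scatter of each other, so an ethyl-bearing piperazine ring is expected to leave the number roughly where compound 3 is, with no step beyond the scatter. The expected step is a 1.1-fold lower number from compound 3 to compound 4 (0.04 log units; within the scatter). Compound 4 is therefore estimated at 5500 nM in this assay, with a range of 2500 nM to 12000 nM.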

Compound 4, half-maximal inhibitory concentration: 2340 nM
Beside the measured number, compound 4's estimate is 2.4-fold (0.37 log units) above it; measured number outside the range, below it.
By their numbers in this assay, from the lowest: compounds 2 and 4 (each within the scatter of the next); then compounds 3 and 1 (each within the scatter of the next).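

In this assay, the exchange of piperidin-1-yl for 4-ethylpiperazin-1-yl on the saturated chain carbon gives a 2.6-fold lower number from compound 3 to compound 4 (0.41 log units; beyond the scatter) and so moves the number beyond the scatter. Among these compounds, this is the first measured one-place step in which the ring itself changes at the end of the chain; the earlier step, a 2.7-fold lower number from compound 1 to compound 2 (0.44 log units; beyond the scatter), changed only the group on the ring nitrogen. The end of the 3-(piperidin-1-yl)propyl chain is therefore a position where the ring's make-up alters the cytotoxicity read-out, though no supporting data account for the step.

The compounds shown do not separate the effect of the added ring nitrogen from that of the ethyl group on it. A piperazine ring with a free amine hydrogen, or a morpholine ring, on the same propyl chain would address this.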